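A Methyl on the Aromatic Ring of a Lactone Core

This account rests on a few compounds, and the source may have more. Where it says the series, first, only, none or still open, it means among the compounds named here.

Measured compounds:
compound 1, `C=C1C(=O)ON(C)C1C(C)CCC`, 340 nM
compound 2, `C=C1C(=O)ON(C)C1c1ccccc1`, 4960 nM

In a functional assay on NALM-6 cells (Homo sapiens) for antiproliferative activity (on this read-out higher numbers stand for weaker inhibition and lower numbers for stronger inhibition), compound 1 gives 340 nM, whereas compound 2 gives 4960 nM, the highest of the two numbers shown; compound 1 sits a good deal lower, and this gap lies beyond the usual scatter of repeated measurements. Compound 3, `C=C1C(=O)ON(C)C1c1ccc(C)cc1`, has not yet been measured. It differs from compound 2 in one place: methyl in place of hydrogen on an aromatic carbon. Within the data shown here, no pair of measured compounds shows what such a change does here, so there is no step to lean on. Among the measured compounds shown here, with only a single small carbon group added to the ring, a step of no more than modest size in this assay is expected, possibly none beyond the scatter. Compound 3 is therefore estimated at 3000 nM, within a range from 900 nM to 10000 nM. The expected step of a 1.7-fold lower number from compound 2 to compound 3 (0.22 log units; within the scatter) is small.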

Compound 3, half-maximal inhibitory concentration: 5800 nM
The estimate for compound 3 lay 1.9-fold (0.29 log units) below the measured number; measured number inside the range.
By their numbers in this assay, from the lowest: compound 1; then compounds 2 and 3 (each within the scatter of the next).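

In this assay, methyl in place of hydrogen on an aromatic carbon, para to a group of 8 heavy atoms, gives a 1.2-fold higher number from compound 2 to compound 3 (0.07 log units; within the scatter) and so leaves compound 2 and compound 3 indistinguishable. Among these compounds, this is the first direct reading of the change, since no earlier pair of compounds showed it: at this one position, a single added carbon produces no difference that can be told from measurement noise. No accompanying measurement offers any explanation for this result.

As far as these compounds go, it remains open whether a larger or chemically different group on the same carbon, such as a longer chain, an amine or a carboxylic acid, would shift the number beyond the scatter. One methyl at one position also cannot show how the ring would respond to the same group on another of its carbons.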